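The source may report more compounds than this note shows. Statements on the series, on what has been measured and on what is new or still open speak of the compounds shown alone.

Measured so far:
- compound 1 `CCN(CC)S(=O)(=O)c1ccc(S(=O)(=O)N2CCC[C@@H](C(=O)NC3CN(C(=O)C4CC4)C3)C2)cc1` — 2800 nM
- compound 2 `CCN(CC)S(=O)(=O)c1ccc(S(=O)(=O)N2CCC[C@@H](C(=O)N3CCN(C(=O)OC(C)(C)C)CC3)C2)cc1` — 70 nM
- compound 3 `CCOC(=O)N1CCC[C@@H](S(=O)(=O)c2ccc(S(=O)(=O)N(CC)CC)cc2)C1` — > 30000 nM (a limit)

All three were run in a functional assay on MIA PaCa-2 cells (Homo sapiens) for inhibition, read by MTT assay, with a stated time of 7 days; on this read-out lower numbers stand for stronger inhibition and higher numbers for weaker inhibition. Of the two numbers, compound 2 gives the lower, compound 1 the higher, and the gap between them lies beyond the usual scatter. Compound 3 does not give a number at all; it sits at the limit of > 30000 nM in this assay, at which 1 of the 3 values shown sits, so nothing more can be drawn from it than that.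

Compound 4 `CCN(CC)S(=O)(=O)c1ccc(S(=O)(=O)N2CCC[C@@H](C(=O)N3CCN(c4nnc(C(C)C)o4)CC3)C2)cc1` is not yet measured. It keeps the shared core of compound 2 and differs in one place: 5-isopropyl-1,3,4-oxadiazol-2-yl in place of tert-butoxycarbonyl on an amine nitrogen in a ring. Both groups sit on the same ring nitrogen of the six-membered non-aromatic ring, and both are neutral with a similar count of heavy atoms; the one entering is aromatic, the one leaving is not. Among the compounds with values here, no measured pair in this set shows what such an exchange does, so the direction has to be left open. The expectation is a step of a 1.7-fold higher number from compound 2 to compound 4 (0.23 log units; within the scatter), which is small enough to fall inside or only a little beyond the scatter. Compound 4 is therefore estimated at 120 nM, with a range from 30 nM to 500 nM.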

Compound 4, half-maximal inhibitory concentration: 1800 nM
Beside the measured number, compound 4's estimate is 15-fold (1.18 log units) below it; measured number outside the range, above it.
By their numbers in this assay, from the lowest: compound 2; then compounds 4 and 1 (each within the scatter of the next). At a limit, above all of these: compound 3.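

In this assay, within the data shown here, the exchange of tert-butoxycarbonyl for 5-isopropyl-1,3,4-oxadiazol-2-yl on an amine nitrogen in a ring gives a 26-fold higher number from compound 2 to compound 4 (1.41 log units; beyond the scatter) and is the first single-place change that can be read. The result shows that this position on the six-membered non-aromatic ring is sensitive to the group it carries, even though both groups have no net charge and no hydrogen-bond donors. The exchange removes a carbonyl-bearing chain without a ring and brings in a five-membered aromatic ring with 3 hetero atoms, so these differences cannot be separated here, and nothing measured in the series gives a cause for the step.

The compounds shown leave open whether the loss follows from the aromatic ring or from the missing carbamate carbonyl, which a smaller ethoxycarbonyl group, an acetyl group or a phenyl ring on the same nitrogen would help to separate. Also open, on these data alone, is how a free secondary amine at this nitrogen would read, and whether a methyl or cyclopropyl group in place of the isopropyl on the oxadiazole would move the number.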